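Bromo to cyano on a sulfonyl aryl ring, second core

The source may hold more compounds than are shown below. What is called first, only, known or untested is meant among the compounds shown, and "the series" means these compounds.

The measured compounds, all read in a functional assay on HepG2 cells (Homo sapiens) for cytotoxicity, read by MTT assay, with a stated time of 24 h; on this read-out lower numbers stand for stronger inhibition and higher numbers for weaker inhibition:
compound 1, `O=C1/C(=C/c2ccccc2F)CN(S(=O)(=O)c2ccc(Br)cc2)C/C1=C\c1ccccc1F`, gives 13700 nM;
compound 2, `N#Cc1ccc(S(=O)(=O)N2C/C(=C\c3ccccc3F)C(=O)/C(=C/c3ccccc3F)C2)cc1`, gives 16500 nM;
compound 3, `O=C1/C(=C/c2ccc(F)cc2)CN(S(=O)(=O)c2ccc(Br)cc2)C/C1=C\c1ccc(F)cc1`, gives 8000 nM.

Compound 1 and compound 2 share one core and differ in a single place, (cyano in place of bromo on an aromatic carbon). Across this change the read-out in this assay moved a 1.2-fold higher number from compound 1 to compound 2 (0.08 log units; within the scatter), a step that stays within the usual scatter of the measurement.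

Compound 3 carries a second core, built from the same atoms as compound 1 but joined differently; the difference between the two cores is not broken down here. Against the other two measured compounds, compound 3 stands at the lowest number, with compound 1 within the scatter of it and compound 2 just beyond it.

Compound 4, `N#Cc1ccc(S(=O)(=O)N2C/C(=C\c3ccc(F)cc3)C(=O)/C(=C/c3ccc(F)cc3)C2)cc1`, has not yet been measured. It stands to compound 3 as compound 2 stands to compound 1, (cyano in place of bromo on an aromatic carbon), the same change at the same kind of place, para to a large group on the sulfonyl aryl ring.

Because the step of a 1.2-fold higher number from compound 1 to compound 2 (0.08 log units; within the scatter) was small, compound 4 is expected to sit close to compound 3 in this assay, and the step of a 1.2-fold higher number from compound 3 to compound 4 (0.07 log units; within the scatter) is estimated to be of that modest size. For compound 4 the estimate in this assay is 9500 nM, expected to fall between 5000 nM and 18000 nM.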

Compound 4, half-maximal inhibitory concentration: 9800 nM
Compound 4: the middle estimate sits 1.0-fold (0.01 log units) below what was measured, and the stated range covers the measured number.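

In this assay, cyano in place of bromo on an aromatic carbon of the sulfonyl aryl ring gives a 1.2-fold higher number from compound 3 to compound 4 (0.09 log units; within the scatter), and on these numbers the two compounds cannot be told apart. Set beside the step on the first core, the change carries over from one core to the other at the same small size: the same change on two cores in this assay, a 1.2-fold higher number (0.08 log units; within the scatter) from compound 1 to compound 2 and a 1.2-fold higher number (0.09 log units; within the scatter) from compound 3 to compound 4, 1.0-fold (0.01 log units) apart, within the scatter of two such steps

Among the compounds shown here, what this agreement does not show is that the two groups are interchangeable in general, since neither step rises beyond the scatter, and two small steps say only that this exchange leaves no readable mark on these two cores in this one cytotoxicity read-out, not how a step of readable size would travel between cores.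

The compounds shown leave open whether another group at the same place on the sulfonyl aryl ring, such as an amine, a carboxylic acid or a methoxy group, would give a step beyond the scatter on either core. They also leave open whether the bromo to cyano step would stay this small on a core carrying methyl or chloro groups where these cores carry fluoro.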